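This account rests on a few compounds, and the source may have more. Where it says the series, first, only, none or still open, it means among the compounds named here.

Measured in an ADME assay on BHK cells (Mesocricetus auratus) for cytotoxicity, read by MTT assay, with a stated time of 96 h; on this read-out lower numbers stand for higher toxicity in this test and higher numbers for lower toxicity in this test:
Compound 1 `FC(F)(F)c1cccc(NC(=S)Nc2cccc(Br)c2)c1`: 10000 nM
Compound 2 `CSCCCNC(=S)Nc1cccc(C(F)(F)F)c1`: > 100000 nM (a limit of the assay)

Compound 2 has no number on this read-out and stands at the limit of > 100000 nM in this assay, at which 1 of the 2 values shown sits. Compound 3 `FC(F)(F)c1cccc(NC(=S)Nc2ccccc2Br)c1` has not yet been measured. Going from compound 2 to compound 3, (2-bromophenyl in place of 3-(methylsulfanyl)propyl on an amide-type nitrogen). Within the data shown here, one measured step bears on this change: an at least 10-fold higher number from compound 1 to compound 2 (1.00 log units; beyond the scatter), which put 3-(methylsulfanyl)propyl in place of 3-bromophenyl on an amide-type nitrogen. Compound 3 reverses that exchange, except that it carries 2-bromophenyl where compound 1 carries 3-bromophenyl. The closest guide is therefore compound 1, with 10000 nM in this assay. The expected step is an at least 8.3-fold lower number from compound 2 to compound 3 (0.92 log units; beyond the scatter), towards lower numbers and beyond the scatter. For compound 3 the estimated value is 12000 nM, with an expected range of 4000 nM to 40000 nM.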

Compound 3, half-maximal cytotoxic concentration: 59000 nM
Compound 3: the middle estimate sits 4.9-fold (0.69 log units) below what was measured; measured number outside the range, above it.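

In this assay, the group on the amide-type nitrogen matters beyond the choice between a ring and a chain: 2-bromophenyl in place of 3-bromophenyl gives a 5.9-fold higher number from compound 1 to compound 3 (0.77 log units; beyond the scatter). Two bromophenyl groups with the same atoms therefore do not read alike here, and compound 3 lies closer to the top of the tested range than compound 1 does. Against the chain, 2-bromophenyl in place of 3-(methylsulfanyl)propyl gives an at least 1.6-fold lower number from compound 2 to compound 3 (0.22 log units; that floor lies within the scatter), and that floor lies within the scatter.

Compound 2 carries only a limit, not a number: the limit of > 100000 nM in this assay, at which 1 of the 3 values shown sits.

The compounds shown leave open how an unsubstituted phenyl ring, or a chain ending in an amine or a carboxylic acid, would read at this nitrogen.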